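The source may report more compounds than this note shows. Statements on the series, on what has been measured and on what is new or still open speak of the compounds shown alone.

Measured compounds:
Compound 1, `O=c1cc(I)n([C@@H]2O[C@H](CO)[C@@H](O)[C@H]2O)c(=O)[nH]1`: in a functional assay on COLO 205 cells (Homo sapiens) for antiproliferative activity, read by WST assay, with a stated time of 3 days (on this read-out lower numbers stand for stronger inhibition and higher numbers for weaker inhibition), compound 1 gives > 50000 nM, which is a limit of the assay and not a number.
Compound 2, `O=c1[nH]c(=O)n([C@@H]2O[C@H](CO)[C@@H](O)[C@H]2O)c(I)c1F`: in this assay compound 2 gives > 50000 nM, again a limit of the assay.

Going by the values given here, compound 2 therefore stands only at a limit, and the one other value shown, that of compound 1, is a limit as well (the limit of > 50000 nM in this assay, at which 2 of the 2 values shown sit). Among the compounds with values here, the single measured step, fluoro in place of hydrogen on an aromatic carbon, is a step that the two limits leave unreadable from compound 1 to compound 2, so its size cannot be read.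

Compound 3, `Nc1c(F)c(=O)[nH]c(=O)n1[C@@H]1O[C@H](CO)[C@@H](O)[C@H]1O`, has not yet been measured. It differs from compound 2 by amino in place of iodo on an aromatic carbon. No measured step bears directly on an amino entering in place of an iodo; the only step shown, from compound 1 to compound 2, is unreadable, so no size or direction can be drawn from it for this assay. With both measured values sitting at the limit, it is expected that compound 3 stays near or at that limit, with a step of an at least 1.6-fold lower number from compound 2 to compound 3 (0.22 log units; that floor lies within the scatter) estimated. The estimate for compound 3 is 30000 nM, with a range from 2000 nM to 50000 nM.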

Compound 3, half-maximal inhibitory concentration: 3300 nM
The estimate for compound 3 lay 9.1-fold (0.96 log units) above the measured number; the range from low to high includes it.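

In this assay, amino in place of iodo on an aromatic carbon, next to the ring nitrogen and ortho to a fluoro group, gives an at least 15-fold lower number from compound 2 to compound 3 (1.18 log units; beyond the scatter). This position is therefore the first place in the compounds shown where a change gives a readable number, and compound 3 is the only one of them whose value is not a limit of the assay. The step has only a floor and its full size stays unknown, as the value of compound 2 is a limit: the limit of > 50000 nM in this assay, at which 2 of the 3 values shown sit.

Whether the fluoro group plays any part in the value of compound 3 stays open: the one step that brings it in cannot be read, and the compounds shown do not tell how the amino group would fare with hydrogen in its place. They also do not tell whether the drop in the number belongs to the amino group alone or would also come with a methylamino, a dimethylamino or a hydroxyl group at the same position.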